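Swapping the Aromatic Tail of Compound 2 for Pentyl

The source may hold more compounds than are shown below. What is called first, only, known or untested is meant among the compounds shown, and "the series" means these compounds.

Compound 1 `O=C(O)CCc1ccc(C#CCc2ccccc2)cc1`: 103%
Compound 2 `O=C(O)CCc1ccc(C#CCCc2ccccc2)cc1`: 128%

Within the data shown here, in a functional assay on 1321-N1 cells for agonist activity at Free fatty acid receptor 1 (Homo sapiens), read by calcium flux, with a stated time of 0.4 s (a higher number here means a larger maximal response, a lower number a smaller maximal response), compound 2 gives 128%, the higher of the two numbers measured so far. Among the measured compounds shown here, compound 1 gives 103%, and the one step recorded, a number 25 percentage points higher from compound 1 to compound 2 (beyond the scatter), lies beyond the scatter. Compound 3 `CCCCCCCC#Cc1ccc(CCC(=O)O)cc1` has not been measured. It differs from compound 2 by pentyl in place of phenyl on a saturated chain carbon, two bonds along the chain from a triple-bonded carbon. For the measured compounds named here, no measured step exchanges an aromatic ring for an open chain; the only step known, a number 25 percentage points higher from compound 1 to compound 2 (beyond the scatter), moves the ring one saturated carbon further from the triple bond and does not show how pentyl in place of phenyl will read. The change is therefore expected to give a step of about a number 13 percentage points lower from compound 2 to compound 3 (beyond the scatter), with the direction uncertain. Compound 3 is estimated at 115% in this assay, expected to fall between 85% and 145%.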

Compound 3, largest response reached (reported as efficacy), in percent of the reference or control that the assay uses: 84%
Beside the measured number, compound 3's estimate is 31 percentage points above it; the measured number lies below the stated range.
By their numbers in this assay, from the lowest: compound 3; then compound 1; then compound 2.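

In this assay, among these compounds, pentyl in place of phenyl on a saturated chain carbon, two bonds along the chain from a triple-bonded carbon, gives a large step, a number 44 percentage points lower from compound 2 to compound 3 (beyond the scatter), and this is the first step here that exchanges an aromatic ring for an open chain. The shorter ring-bearing chain also stands higher than the open chain, a number 19 percentage points lower from compound 1 to compound 3 (beyond the scatter), so compound 3 has the lowest maximal response of the three, and both ring-bearing compounds read higher than the ring-free one. Nothing available explains what lies behind these steps.

The compounds shown leave open whether a cyclohexyl group at this place would read like phenyl or like pentyl. They also leave open how a pyridine ring or a longer open chain would read there.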